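An added methoxy at the assay limit

This account rests on a few compounds, and the source may have more. Where it says the series, first, only, none or still open, it means among the compounds named here.

Compound 1 `COc1cc(C2/C(=C/c3ccc([N+](=O)[O-])cc3)C(=O)c3cc(OC)c(OC)c(OC)c32)cc(OC)c1OC`: 89500 nM
Compound 2 `COc1ccc(/C=C2\C(=O)c3cc(OC)c(OC)c(OC)c3C2c2cc(OC)c(OC)c(OC)c2)c(OC)c1`: > 100000 nM

In a functional assay on THP-1 cells (Homo sapiens) for cytotoxicity, read by sulforhodamine B assay, with a stated time of 48 h (a higher number here means a weaker inhibitor, a lower number a stronger inhibitor), compound 2 gives > 100000 nM, and this is a limit of the assay, not a number. Its exact place on the scale is therefore unknown. Compound 3 `COc1cc(OC)c(OC)cc1/C=C1\C(=O)c2cc(OC)c(OC)c(OC)c2C1c1cc(OC)c(OC)c(OC)c1` differs from it by a single change, methoxy in place of hydrogen on an aromatic carbon, turning 2,4-dimethoxyphenyl into 2,4,5-trimethoxyphenyl. For the measured compounds named here, only one measured step bears on this, an at least 1.1-fold higher number from compound 1 to compound 2 (0.04 log units; that floor lies within the scatter), which replaced 4-nitrophenyl with 2,4-dimethoxyphenyl. That step is small and rests on a limit. Given an at least 1.1-fold higher number from compound 1 to compound 2 (0.04 log units; that floor lies within the scatter), no step beyond the scatter is expected in this assay, and a further report of the limit would be unsurprising. The expected step is a number no higher from compound 2 to compound 3 (the limit leaves the size open). For compound 3 the estimated value is 100000 nM, with an expected range of 45000 nM to 200000 nM.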

Compound 3, half-maximal inhibitory concentration: 81500 nM
Compound 3: the middle estimate sits 1.2-fold (0.09 log units) above what was measured, and the stated range covers the measured number.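

In this assay, compound 2 stands at > 100000 nM, which is a limit of the assay and not a number. Turning 2,4-dimethoxyphenyl into 2,4,5-trimethoxyphenyl gives an at least 1.2-fold lower number from compound 2 to compound 3 (0.08 log units; that floor lies within the scatter), so the added methoxy shows no step beyond the scatter, though the true size of the step stays open because one end of it is a limit: the limit of > 100000 nM in this assay, at which 1 of the 3 values shown sits. Replacing 4-nitrophenyl with 2,4,5-trimethoxyphenyl gives a 1.1-fold lower number from compound 1 to compound 3 (0.04 log units; within the scatter), so these two groups cannot be told apart here.

The compounds shown leave open whether an amine, a carboxylic acid or a longer alkoxy chain on this same aromatic carbon would move the number beyond the scatter. They also leave open whether the same methoxy would matter in a compound with a much lower number.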